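This account rests on a few compounds, and the source may have more. Where it says the series, first, only, none or still open, it means among the compounds named here.

Of the compounds shown here, three sharing one core have so far been measured in a functional assay on MCF7 cells (Homo sapiens) for inhibition, read by MTT assay, with a stated time of 72 h; on this read-out lower numbers stand for stronger inhibition and higher numbers for weaker inhibition. Compound 1 `Cc1ccc(NC(=O)c2ccc(/N=N\c3c[nH]c4ccccc34)cc2)c(C)c1` gives 87000 nM in this assay, and compound 2 `COc1ccccc1NC(=O)c1ccc(/N=N\c2c[nH]c3ccccc23)cc1` gives 86500 nM. Compound 3 `O=C(Nc1ccc([N+](=O)[O-])cc1)c1ccc(/N=N\c2c[nH]c3ccccc23)cc1` gives 54500 nM, the lowest of the three numbers, though the gaps to compound 2 and to compound 1 are both within the usual scatter, so no ordering among them can be claimed. The unmeasured compound 4 `Cc1cccc(NC(=O)c2ccc(/N=N\c3c[nH]c4ccccc34)cc2)c1` is reached from compound 3 by one change: 3-methylphenyl in place of 4-nitrophenyl on an amide-type nitrogen. Among the compounds with values here, the steps that bear on this change are the ones leading into compound 3, in which 4-nitrophenyl replaced another aryl group on the same amide-type nitrogen: a 1.6-fold lower number from compound 1 to compound 3 (0.20 log units; within the scatter) and a 1.6-fold lower number from compound 2 to compound 3 (0.20 log units; within the scatter). Both were small, and the present change runs the other way, replacing 4-nitrophenyl with a group that, like those of compound 1 and compound 2, carries no hydrogen-bond acceptors. On that basis the step of a 1.6-fold higher number from compound 3 to compound 4 (0.19 log units; within the scatter) is expected to be small and, if anything, toward a slightly higher number, not beyond the scatter. Compound 4 is therefore estimated at 85000 nM in this assay, with a range from 40000 nM to 180000 nM.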

Compound 4, half-maximal inhibitory concentration: 73400 nM
Compound 4: middle estimate off by 1.2-fold (0.06 log units), on the high side, within the range that was stated.
By their numbers in this assay, from the lowest: compounds 3, 4, 2 and 1 (each within the scatter of the next).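

In this assay the 3-methylphenyl group on the amide-type nitrogen stays within the scatter of all three aryl groups measured before it, with a 1.3-fold higher number from compound 3 to compound 4 (0.13 log units; within the scatter), a 1.2-fold lower number from compound 2 to compound 4 (0.07 log units; within the scatter) and a 1.2-fold lower number from compound 1 to compound 4 (0.07 log units; within the scatter). The new point is that this holds even when 4-nitrophenyl, with its nitrogen, its oxygens and its hydrogen-bond acceptors, gives way to a group made of carbon only, so all four aryl groups now lie within the scatter of one another and no ordering among them can be claimed at this position. Nothing available here explains why these four aryl groups read alike.

The compounds shown leave open whether anything other than a substituted phenyl on this nitrogen, such as a longer alkyl chain, a pyridine ring or a phenyl carrying an amine or a carboxylic acid, would give a step beyond the scatter. They also leave open whether a change elsewhere in the shared core, rather than on this nitrogen, would separate these compounds in this assay.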